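This account rests on a few compounds, and the source may have more. Where it says the series, first, only, none or still open, it means among the compounds named here.

The three measured compounds share one core and differ only in the group on a saturated chain carbon bound to an amine nitrogen in a ring. Compound 1 `Clc1cc(Cl)cc(CO[C@H]2CCCN(Cc3ccccn3)[C@H]2c2ccccc2)c1` carries pyridin-2-yl there, and in an assay on isolated protein for activation of cGMP-dependent protein kinase 1 (Homo sapiens), read by ADP-Glo, with stated times of 120 min and 40 min (on this read-out lower numbers stand for an effect already at smaller amounts and higher numbers for an effect only at larger amounts of compound), compound 1 reaches only a limit, > 200000 nM. Compound 2 `Clc1cc(Cl)cc(CO[C@H]2CCCN(Cc3ccccc3)[C@H]2c2ccccc2)c1` carries phenyl, and in this assay compound 2 likewise reaches only a limit, > 200000 nM. Among the compounds with values here, compound 3 `Clc1cc(Cl)cc(CO[C@H]2CCCN(Cc3cccnc3)[C@H]2c2ccccc2)c1` carries pyridin-3-yl and is the only one with a number: in this assay compound 3 gives 112000 nM. The steps of an at least 1.7-fold lower number from compound 1 to compound 3 (0.25 log units; that floor lies within the scatter) and an at least 1.7-fold lower number from compound 2 to compound 3 (0.25 log units; that floor lies within the scatter) both start from the limit (the limit of > 200000 nM in this assay, at which 2 of the 3 values shown sit), so only a floor of their size can be read. Compound 4 `Cn1ccnc1CN1CCC[C@H](OCc2cc(Cl)cc(Cl)c2)[C@@H]1c1ccccc1` differs from compound 3 by 1-methyl-1H-imidazol-2-yl in place of pyridin-3-yl on a saturated chain carbon bound to an amine nitrogen in a ring. The two measured steps show that swapping this group has shifted the read-out by no more than a barely readable amount, two of three groups giving only a limit. Compound 4 is therefore expected to sit near the limit again, with an estimated step of a 1.6-fold higher number from compound 3 to compound 4 (0.21 log units; within the scatter). The estimate for compound 4 is 180000 nM, between 80000 nM and 400000 nM.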

Compound 4, half-maximal effective concentration: 165000 nM
Compound 4: the middle estimate sits 1.1-fold (0.04 log units) above what was measured, and the stated range covers the measured number.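

With a 1.5-fold higher number from compound 3 to compound 4 (0.17 log units; within the scatter), the result shows that 1-methyl-1H-imidazol-2-yl, a five-membered aromatic ring with 2 hetero atoms, can replace pyridin-3-yl at this place and still give a number in this assay, one that cannot be told apart from the number for the six-membered ring. Against the two compounds that reach only a limit, the steps are an at least 1.2-fold lower number from compound 2 to compound 4 (0.08 log units; that floor lies within the scatter) and an at least 1.2-fold lower number from compound 1 to compound 4 (0.08 log units; that floor lies within the scatter), and both are only floors, as they start from a limit: the limit of > 200000 nM in this assay, at which 2 of the 4 values shown sit.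

Pyridin-3-yl and 1-methyl-1H-imidazol-2-yl are thus the two groups here that give a number, and no step among the groups shown is printed as beyond the scatter.

The compounds shown leave open whether any group at this place, such as an amine or a carboxylic acid, could lower the number beyond the scatter. They also leave open whether a change elsewhere on the shared core would move the read-out further.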